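Methoxycarbonyl to carboxy on compound 2

This account rests on a few compounds, and the source may have more. Where it says the series, first, only, none or still open, it means among the compounds named here.

In a functional assay on DU-145 cells (Homo sapiens) for cytotoxicity, read by MTT assay (on this read-out higher numbers stand for weaker inhibition and lower numbers for stronger inhibition), the measured compounds are these
- compound 1 (`COC(=O)C[C@H]1C[C@@H](O)[C@@H](C)[C@@H](c2ccc(OC)cc2)N1`) gives 12600 nM
- compound 2 (`COC(=O)C[C@H]1C[C@H](O)[C@@H](C)[C@@H](c2ccc(OC)cc2)N1`) gives 6500 nM

Compound 2 lies within the scatter of compound 1, so the two cannot be ranked in this assay. Compound 3 (`COc1ccc([C@H]2N[C@@H](CC(=O)O)C[C@H](O)[C@H]2C)cc1`) differs from compound 2 by one change (hydrogen in place of methyl on an oxygen next to a carbonyl group), hydrogen in place of methyl on an oxygen next to a carbonyl group, or methoxycarbonyl to carboxy. Going by the values given here, the sole measured step (a 1.9-fold lower number from compound 1 to compound 2 (0.29 log units; within the scatter)) reflects the fact that compounds 1 and 2 differ only in the configuration as drawn and leaves the methoxycarbonyl group untouched, so it gives no size for this change. A modest move towards a higher number is expected, with wide uncertainty. The estimated step is a 2.5-fold higher number from compound 2 to compound 3 (0.39 log units; beyond the scatter) in this assay. Compound 3 is expected at about 16000 nM (estimated range 5000 nM to 60000 nM) in this assay.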

Compound 3, half-maximal inhibitory concentration: 15700 nM
Estimate against measurement, compound 3: 1.0-fold (0.01 log units) above; the measured number falls inside the stated range.
By their numbers in this assay, from the lowest: compounds 2, 1 and 3 (each within the scatter of the next, the first and the last beyond it).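

In this assay, going by these compounds alone, the exchange of methoxycarbonyl for carboxy gives a 2.4-fold higher number from compound 2 to compound 3 (0.38 log units; beyond the scatter), which is the first measured size for any change at this position, since the earlier pair shared the methoxycarbonyl group. The step is modest: removing the methyl from the oxygen next to the carbonyl group does not abolish the read-out, and compound 3 still gives 15700 nM. The information at hand offers no explanation for the size of this step.

The compounds shown leave open how an ethyl ester, a primary amide or a longer chain in place of the (methoxycarbonyl)methyl group would read in this assay. They also leave open whether the same change, made on compound 1, would give a step of similar size.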